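The compounds below may be only part of what the source reports. "The series", "measured", "known", "first", "only" and "open" are said of these compounds alone.

Compounds measured in a functional assay on MDA-MB-231 cells (Homo sapiens) for antiproliferative activity, read by MTT assay, with a stated time of 24 h; a lower number here means a stronger inhibitor, a higher number a weaker inhibitor:
- Compound 1 `Cc1cccc(NNC(=O)c2ccccc2NS(=O)(=O)c2cnc(O)nc2O)c1`: > 20000 nM, a limit of the assay
- Compound 2 `O=C(NNc1ccccc1Cl)c1ccccc1NS(=O)(=O)c1cnc(O)nc1O`: 18900 nM
- Compound 3 `CCCCOc1ccc(C(=O)NNC(=O)c2ccccc2NS(=O)(=O)c2cnc(O)nc2O)cc1`: 6830 nM

Compound 3 has the lower of the two actual numbers, and its gap to compound 2 lies beyond the scatter. The next compound is compound 4 `O=C(NNC(=O)c1ccccc1NS(=O)(=O)c1cnc(O)nc1O)c1ccccc1F`, where 2-fluorophenyl takes the place of 4-butoxyphenyl on a carbonyl carbon: 2-fluorophenyl in place of 4-butoxyphenyl on a carbonyl carbon.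

Among the compounds with values here, the only measured step offers little guidance. an at least 1.0-fold lower number from compound 1 to compound 2 (0.02 log units; that floor lies within the scatter) is within the scatter, and it falls on an amine nitrogen, not at the site changed here. Within the data shown here, no measured step isolates the loss of 4-butoxyphenyl, so the expectation is tentative. Compound 3 alone carries that group, while compound 2, with 2-chlorophenyl, stands at 18900 nM. A move to a higher number, beyond the scatter, is therefore expected in this assay. The estimated step is a 1.8-fold higher number from compound 3 to compound 4 (0.24 log units; within the scatter). For compound 4 the expected value is 12000 nM, with an estimated range of 5000 nM to 25000 nM.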

Compound 4, half-maximal inhibitory concentration: > 20000 nM
Compound 4 was reported as a limit (the forecaster's own chance of this, stated with the estimate: 30%); at least 1.6-fold (0.22 log units) between middle value and limit.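

In this assay compound 4 gives > 20000 nM, which is a limit of the assay and not a number. Within the data shown here, on the carbonyl carbon, exchanging 4-butoxyphenyl for 2-fluorophenyl gives an at least 2.9-fold higher number from compound 3 to compound 4 (0.46 log units; beyond the scatter), the first readable step at this site, so the activity seen with compound 3 does not carry over to this replacement. The remaining comparisons add little, as an at least 1.0-fold higher number from compound 2 to compound 4 (0.02 log units; that floor lies within the scatter) is only a floor. The step between compound 1 and compound 4 cannot be read, and the limit constrains both comparisons: the limit of > 20000 nM in this assay, at which 2 of the 4 values shown sit.

Going by these compounds, it remains open how far compound 4 lies beyond its limit. The compounds shown also do not reveal whether the butoxy chain itself accounts for the difference, which a methoxy group or a longer alkoxy chain in its place on the phenyl ring could address.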